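The source may hold more compounds than are shown below. What is called first, only, known or untested is meant among the compounds shown, and "the series" means these compounds.

In an ADME assay on microsomes from liver (Homo sapiens) for metabolic stability, with a stated time of 60 min, tested at 1 uM (a higher number here means that more of the compound is left, a lower number that less of the compound is left), compound 2 `CS(=O)(=O)Nc1ccc2c(c1)S(=O)(=O)N=C(C1=C(O)[C@@H]3[C@H]4CC[C@H](C4)[C@@H]3N(Cc3ccc(F)c(Cl)c3)C1=O)N2` gives 87%, which lies within the scatter of compound 1 `CS(=O)(=O)Nc1ccc2c(c1)S(=O)(=O)N=C(C1=C(O)[C@@H]3[C@H]4CC[C@H](C4)[C@@H]3N(Cc3ccccc3)C1=O)N2` at 80%. Both compounds are therefore well retained in this assay, and neither can be set apart from the other. Compound 3 `CS(=O)(=O)Nc1ccc2c(c1)S(=O)(=O)N=C(C1=C(O)[C@@H]3[C@H]4CC[C@H](C4)[C@@H]3N(Cc3ccc(F)c(F)c3F)C1=O)N2` shares their core and differs from compound 2 at one place: 2,3,4-trifluorophenyl in place of 3-chloro-4-fluorophenyl on a saturated chain carbon bound to an amide-type nitrogen in a ring, with 2,3,4-trifluorophenyl in place of 3-chloro-4-fluorophenyl on a saturated chain carbon bound to an amide-type nitrogen in a ring. For the measured compounds named here, the one measured step at this place is a number 7 percentage points higher from compound 1 to compound 2 (within the scatter), where 3-chloro-4-fluorophenyl replaced phenyl. Going by the values given here, no measured compound yet carries 2,3,4-trifluorophenyl. Among the compounds with values here, with only that step to go on, no change beyond the scatter is expected in this assay, in either direction. For compound 3 the estimated value is 84%, with an expected range of 70% to 95%. This estimate amounts to an expected a number 3 percentage points lower from compound 2 to compound 3 (within the scatter).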

Compound 3, percent of the compound remaining: 100%
Compound 3: the middle estimate sits 16 percentage points below what was measured; measured number outside the range, above it.
By their numbers in this assay, from the lowest: compounds 1 and 2 (each within the scatter of the next); then compound 3.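

In this assay the aryl group at this place, on a saturated chain carbon bound to an amide-type nitrogen in a ring, now shows an effect that can be read: 2,3,4-trifluorophenyl gives a number 13 percentage points higher from compound 2 to compound 3 (beyond the scatter) and also a number 20 percentage points higher from compound 1 to compound 3 (beyond the scatter) in the comparison with phenyl. Halogen on the phenyl ring is not enough on its own, since compound 2 stays within the scatter of compound 1 while compound 3 stands clear of both. Nothing given here explains this difference.

The compounds shown leave open whether the gain follows the number of fluorines or the absence of chlorine, which a monofluorophenyl or a dichlorophenyl group could help to separate. They also leave open how a non-aromatic cyclohexyl group or a pyridine ring would fare at this place.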